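From Cyclopentylmethyl to Cyclohexyl on the Shared Core

A few compounds are considered here, and "the series" means these few. Any claim that something is new, unique, unknown or untested is made for them only; others in the source may bear on it.

In a physicochemical assay for lipophilicity (a lower number here means a more polar compound, a higher number a more lipophilic compound), compound 1 `CCCN(C1=NCCN1)c1c(Br)cccc1Br` gives -0.55 and compound 2 `CC(C)=CCN(C1=NCCN1)c1c(Br)cccc1Br` gives -0.14 while compound 3 `Brc1cccc(Br)c1N(CC1CCCC1)C1=NCCN1` gives 0.32 as the highest number of the three. Compound 4 `Brc1cccc(Br)c1N(C1=NCCN1)C1CCCCC1` has cyclohexyl in place of cyclopentylmethyl on a nitrogen on an aromatic ring and holds the same atoms as compound 3, joined differently. Within the data shown here, no measured step makes this exchange. The nearest guides are a number 0.87 log units higher from compound 1 to compound 3 (beyond the scatter) and a number 0.46 log units higher from compound 2 to compound 3 (beyond the scatter) but both of these alter which atoms the group holds, so no step beyond the scatter is expected in this assay here. The estimated step is a number 0.12 log units lower from compound 3 to compound 4 (within the scatter) and stays within the scatter. For compound 4 the estimate is 0.2 with -0.3 to 0.7 as the expected range.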

Compound 4, distribution coefficient: 0.14
For compound 4 the middle estimate is 0.06 log units above the measured one, within the range that was stated.
By their numbers in this assay, from the lowest: compound 1; then compounds 2, 4 and 3 (each within the scatter of the next, the first and the last beyond it).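

On a nitrogen on an aromatic ring in this assay, the exchange of cyclopentylmethyl for cyclohexyl gives a number 0.18 log units lower from compound 3 to compound 4 (within the scatter) and so cannot be told apart from no change. Cyclohexyl in place of 3-methylbut-2-en-1-yl gives a number 0.28 log units higher from compound 2 to compound 4 (within the scatter) and is equally unresolved, while cyclohexyl in place of propyl gives a number 0.69 log units higher from compound 1 to compound 4 (beyond the scatter) and is the only one of these steps to clear the scatter. Nothing available offers an explanation for these steps. From the compounds shown here alone, what a longer chain such as hexyl, or a cyclohexyl ring carrying an amine or a carboxylic acid, would give at this nitrogen remains open.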